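Methyl for hydrogen on the bicyclic core: compound 3 to 4

The source may hold more compounds than are shown below. What is called first, only, known or untested is meant among the compounds shown, and "the series" means these compounds.

Measured so far:
- compound 1 `C[C@H](Oc1ccc(NC(=O)CC(=O)O)c(C2CC2)n1)c1c(Cl)ccc(F)c1Cl`: 1.4
- compound 2 `C[C@H](Oc1ccc2ncc(/C=C/c3nn[nH]n3)c(C(F)F)c2c1)c1c(Cl)cccc1Cl`: 3.3
- compound 3 `C[C@H](Oc1ccc2ncc(/C=C/C(=O)O)cc2c1)c1c(Cl)ccc(F)c1Cl`: 2.5

In a physicochemical assay for lipophilicity, using the shake flask method (on this read-out lower numbers stand for lower lipophilicity and higher numbers for higher lipophilicity), compound 3 stands second highest of the three numbers. Its nearest neighbour is compound 2, whose value 3.3 lies above it by more than the scatter; furthest away is compound 1, whose value 1.4 lies below it by more than the scatter. Going by the values given here, no pair among the three differs in only one place, so no single step between measured compounds is available.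

Compound 4 `Cc1c(/C=C/C(=O)O)cnc2ccc(O[C@@H](C)c3c(Cl)ccc(F)c3Cl)cc12` is the next compound in the series, not yet measured. It differs from compound 3 by methyl in place of hydrogen on an aromatic carbon, the new group sitting ortho to a 2-carboxyethenyl group and ortho to a fused ring, opposite the ring nitrogen.

With no measured step of this kind in the series, the expectation is a small upward move, at or just beyond the scatter, estimated as a number 0.40 log units higher from compound 3 to compound 4 (beyond the scatter). Compound 4 is therefore expected at 2.9, within 2.5 to 3.3.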

Compound 4, distribution coefficient: 3
Compound 4: middle estimate off by 0.10 log units, on the low side, within the range that was stated.
By their numbers in this assay, from the lowest: compound 1; then compound 3; then compounds 4 and 2 (each within the scatter of the next).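

In this assay, methyl in place of hydrogen on the aromatic carbon ortho to the 2-carboxyethenyl group gives a number 0.50 log units higher from compound 3 to compound 4 (beyond the scatter) and is the only single-place step among the compounds shown. The step is modest, yet it shows that one added carbon at this position, opposite the ring nitrogen, is enough to shift the read-out past the scatter while the 2-carboxyethenyl group and the rest of the shared core stay unchanged. Nothing measured here accounts for the size of this step.

On these data alone, whether an amine, a methoxy group or a longer chain such as ethyl on this carbon would give a step of similar size or direction remains open. A single pair also leaves open whether methyl here gives the same step when the 2-carboxyethenyl group is exchanged for another side chain.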